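The compounds below may be only part of what the source reports. "The series", "measured", "known", "first", "only" and "open" are said of these compounds alone.

This account follows the step from compound 3 `Cc1nc(C(=O)NCc2ccccc2)c(O)c(=O)n1C` to compound 4 `Cn1c(Cc2ccccc2C(F)(F)F)nc(C(=O)NCc2ccccc2)c(O)c1=O`, with compound 1 `O=C(NCc1ccccc1)c1nc(Cc2ccccc2C(F)(F)F)[nH]c(=O)c1O` and compound 2 `CC(NC(=O)c1nc(Cc2ccccc2C(F)(F)F)n(C)c(=O)c1O)c1ccccc1` as neighbours. In an ADME assay on HepG2 cells (Homo sapiens) for cytotoxicity, in the presence of a further agent that is not named here (a higher number here means a weaker inhibitor, a lower number a stronger inhibitor), compound 3 gives > 100000 nM, which is a limit of the assay and not a number. Compound 3 therefore has no measured value, and the same holds for the other two compounds, since all the results sit at the limit of > 100000 nM in this assay, at which 3 of the 3 values shown sit.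

Compound 4 differs from compound 3 as follows: 2-(trifluoromethyl)phenyl in place of hydrogen on a saturated chain carbon bound to an aromatic carbon. In words, this is 2-(trifluoromethyl)phenyl in place of hydrogen on a saturated chain carbon bound to an aromatic carbon.

Compound 1 already carries 2-(trifluoromethyl)phenyl and gives > 100000 nM in this assay, again a limit. Compound 2 carries the same group and gives > 100000 nM in this assay, also a limit. Neither compound offers a number against which to size the change, but both suggest that the added group need not bring measurable cytotoxicity. No step beyond the usual scatter is therefore expected in this assay, in either direction.

The estimated change is a number no higher from compound 3 to compound 4 (the limit leaves the size open). For compound 4 the expected value is 100000 nM, with an estimated range of 50000 nM to 200000 nM, and the result may well be reported only as a limit.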

Compound 4, half-maximal inhibitory concentration: > 100000 nM
Compound 4 was reported as a limit (the forecaster's own chance of this, stated with the estimate: 85%); the middle value sits exactly at the limit.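

In this assay compound 4 gives > 100000 nM, which is a limit of the assay and not a number. No step can be read between compound 4 and compound 1, compound 2 or compound 3, which all sit at the same limit: the limit of > 100000 nM in this assay, at which 4 of the 4 values shown sit.

The compounds shown leave open how far any of these changes, including the added 2-(trifluoromethyl)phenyl, would shift the read-out in this assay.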